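Shorter chain and triazole in place of pyridine on the aminoalkyl arm

A few compounds are considered here, and "the series" means these few. Any claim that something is new, unique, unknown or untested is made for them only; others in the source may bear on it.

Working notes on a small set of analogues around the shared core of compound 1 `Cc1cc(NCCCc2ccccn2)n2nc(C)c(-c3ccccc3)c2n1`. In a physicochemical assay for solubility, read by HPLC, using the shake flask method, measured as kinetic solubility, with a stated time of 2 h, at pH 7.4 (on this read-out higher numbers stand for higher solubility and lower numbers for lower solubility), compound 1 gives 5900 nM, the lowest of the three numbers recorded. Compound 2 `Cc1cc(N(C)Cc2ccccn2)n2nc(C)c(-c3ccccc3)c2n1` gives 17500 nM, a step up from compound 1 that lies beyond the scatter. Compound 3 `Cc1cc(NCc2ccccn2)n2ncc(C3=CCOCC3)c2n1` gives 171000 nM, the highest number of the set and far beyond the scatter relative to compound 1. Going by the values given here, no pair here differs in one place only, so these values are read side by side rather than as single steps.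

Compound 4 `Cc1cc(NCc2ncnn2C)n2nc(C)c(-c3ccccc3)c2n1` has not yet been measured in this assay. The change from compound 1 is 1-methyl-1H-1,2,4-triazol-5-yl in place of 2-(pyridin-2-yl)ethyl on a saturated chain carbon bound to a nitrogen on an aromatic ring. The arm attached to the aromatic nitrogen becomes shorter and richer in ring nitrogens. Solubility is expected to rise, with a moderate step of a 4.2-fold higher number from compound 1 to compound 4 (0.63 log units; beyond the scatter) expected, partly because compound 3 gives 171000 nM with a single-carbon linker. For compound 4 the estimate is 25000 nM, within a range from 8000 nM to 80000 nM.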

Compound 4, solubility: 185000 nM
For compound 4 the middle estimate is 7.4-fold (0.87 log units) below the measured one; measured number above the stated range.
By their numbers in this assay, from the lowest: compound 1; then compound 2; then compounds 3 and 4 (each within the scatter of the next).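

In this assay, going by these compounds alone, 1-methyl-1H-1,2,4-triazol-5-yl in place of 2-(pyridin-2-yl)ethyl on a saturated chain carbon bound to a nitrogen on an aromatic ring gives a 31-fold higher number from compound 1 to compound 4 (1.50 log units; beyond the scatter), the first step that can be tied to this one place, with the rest of the structure unchanged. The step is large, so the read-out is highly sensitive to the group at this place, but chain length and ring change together, as the same difference also reads 3-(pyridin-2-yl)propyl to (1-methyl-1H-1,2,4-triazol-5-yl)methyl. No measurement shown here offers an explanation for the step.

Going by these compounds, how much of the step belongs to the chain and how much to the ring stays open, and a 3-(1-methyl-1H-1,2,4-triazol-5-yl)propyl arm on the same core would bear on that. Also open, on these data alone, is how a saturated amine such as morpholine at this place would read in this assay.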